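The compounds below may be only part of what the source reports. "The series", "measured", "known", "first", "only" and "open" are said of these compounds alone.

In an ADME assay on L929 cells (Mus musculus) for cytotoxicity, read by resazurin assay, with a stated time of 72 h (a lower number here means a stronger inhibitor, a higher number a weaker inhibitor), compound 2 `O=C(/C=C/c1ccc2c(c1)B(O)OC2)c1ccc(OCc2ccccc2)cc1` gives > 10 ug/mL, a limit of the assay and not a number. Compound 1 `COc1cc(C(=O)/C=C/c2ccc3c(c2)B(O)OC3)cc(OC)c1OC` is also a limit, at > 10 ug/mL. Compound 3 `COc1cccc(C(=O)CCc2ccc3c(c2)B(O)OC3)c1` is a limit too, at > 10 ug/mL. Among the compounds with values here, the series so far therefore reads: the limit of > 10 ug/mL in this assay, at which 3 of the 3 values shown sit. Within the data shown here, no measured step between these compounds gives a size for any change.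

Compound 4 `O=C(/C=C/c1ccc2c(c1)B(O)OC2)c1ccc([N+](=O)[O-])cc1` has nitro in place of benzyloxy on an aromatic carbon, para to a large group: nitro in place of benzyloxy on an aromatic carbon. With only the limit > 10 ug/mL of compound 2 to start from, no step beyond the scatter is expected in this assay, and no direction is favoured. The expected step is a number no higher from compound 2 to compound 4 (the limit leaves the size open). For compound 4 the estimated value is 10 ug/mL, with an expected range of 4 ug/mL to 20 ug/mL.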

Compound 4, half-maximal inhibitory concentration: > 10 ug/mL
Compound 4 ended at the assay's limit (the forecaster's own chance of this, stated with the estimate: 75%); the middle value sits exactly at the limit.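

In this assay, within the data shown here, compound 2 and compound 4 both give limits of the assay and not numbers, and no step between them can be read. The compounds shown leave open whether any structural change alters cytotoxicity, with every value still a limit: the limit of > 10 ug/mL in this assay, at which 4 of the 4 values shown sit.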